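Ester to aryl ketone at the exocyclic chain of compound 3

The compounds below may be only part of what the source reports. "The series", "measured", "known", "first", "only" and "open" are said of these compounds alone.

Measured compounds:
Compound 1, `CCOC(=O)/C=C1/C(=O)N2[C@@H]1SC(C)(C)[C@@H]2C(=O)OC(c1ccccc1)c1ccccc1`: 7000 nM
Compound 2, `CC1(C)S[C@@H]2/C(=C\C(=O)OCc3ccccc3)C(=O)N2[C@H]1C(=O)OC(c1ccccc1)c1ccccc1`: 7100 nM
Compound 3, `COC(=O)/C=C1/C(=O)N2[C@@H]1SC(C)(C)[C@@H]2C(=O)OC(c1ccccc1)c1ccccc1`: 24600 nM

Three esters of a shared core were measured in a functional assay on A-375 cells (Homo sapiens) for cytotoxicity, read by MTT assay, with a stated time of 48 h; on this read-out higher numbers stand for weaker inhibition and lower numbers for stronger inhibition. Compound 3 stands with the highest number of the three: the step of a 3.5-fold higher number from compound 1 to compound 3 (0.55 log units; beyond the scatter) and the step of a 3.5-fold higher number from compound 2 to compound 3 (0.54 log units; beyond the scatter) both run upward to it, while the step of a 1.0-fold higher number from compound 1 to compound 2 (0.01 log units; within the scatter) shows the ethyl and benzyl esters giving numbers within the scatter of each other.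

Compound 4, `CC1(C)S[C@@H]2/C(=C\C(=O)c3ccc([N+](=O)[O-])cc3)C(=O)N2[C@H]1C(=O)OC(c1ccccc1)c1ccccc1`, is not yet measured. It differs from compound 3 as follows: 4-nitrophenyl in place of methoxy on a carbonyl carbon. The measured steps bear on this only loosely, since each of them swaps one ester alkyl for another, whereas here the ester oxygen itself leaves with its methyl and an aryl ring takes its place on the carbonyl carbon. The only directional hint is that the smallest ester, compound 3, gave the highest number, and that the bulkier groups lowered it modestly, because a 3.5-fold higher number from compound 2 to compound 3 (0.54 log units; beyond the scatter) ran the other way. The author therefore expects a modest step downward in this assay, of roughly the size a 3.1-fold lower number from compound 3 to compound 4 (0.49 log units; beyond the scatter), with wide uncertainty. The estimate for compound 4 is 8000 nM, with a range from 2000 nM to 30000 nM.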

Compound 4, half-maximal inhibitory concentration: 50300 nM
Beside the measured number, compound 4's estimate is 6.3-fold (0.80 log units) below it; measured number outside the range, above it.
By their numbers in this assay, from the lowest: compounds 1 and 2 (each within the scatter of the next); then compound 3; then compound 4.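

In this assay, 4-nitrophenyl in place of methoxy on the carbonyl carbon gave a 2.0-fold higher number from compound 3 to compound 4 (0.31 log units; beyond the scatter) and so moved the number upward, which no exchange among the esters had done starting from the ethyl or benzyl ester with a larger group in view. The same exchange measured against the two larger esters gave a 7.1-fold higher number from compound 2 to compound 4 (0.85 log units; beyond the scatter) and a 7.2-fold higher number from compound 1 to compound 4 (0.86 log units; beyond the scatter) and leaves compound 4 with the highest number of the four, so a large group with a ring on this carbonyl carbon does not by itself go with a lower number, as benzyloxy did. Nothing available here accounts for this rise.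

The compounds shown leave open whether the rise belongs to the ketone or to the nitro group on the ring, a question a plain phenyl ketone would address. Going by these compounds, how an amide or a carboxylic acid on this carbonyl carbon would stand in this assay also remains open.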